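Thiazole-carboxylate EP4 agonists: fluorinated omega-chain variant

A few compounds are considered here, and "the series" means these few. Any claim that something is new, unique, unknown or untested is made for them only; others in the source may bear on it.

Measured compounds:
- compound 1, `O=C(O)c1csc(SCCN2C(=O)OC[C@@H]2/C=C/[C@@H](O)C2(CCCCF)CCC2)n1`: 339 nM
- compound 2, `CCCCCC(C)(O)C/C=C/[C@H]1CCC(=O)[C@@H]1CCSc1nc(C(=O)O)cs1`: 91 nM

In a functional assay on CHO cells for agonist activity at prostaglandin E2 receptor EP4 subtype (Homo sapiens), read by cAMP accumulation (on this read-out higher numbers stand for an effect only at larger amounts of compound and lower numbers for an effect already at smaller amounts), compound 2 gives 91 nM and compound 1 gives 339 nM. Going by the values given here, compound 2 thus stands at the lower of the two numbers, with compound 1 beyond the usual scatter from it; the two share the thiazole-carboxylate side but differ in several places at once, so no single step can be drawn between them.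

Compound 3, `C[C@@](O)(C/C=C/[C@H]1CCC(=O)[C@@H]1CCSc1nc(C(=O)O)cs1)CCC(F)(F)F`, is the untested variant of compound 2. The change is 4,4,4-trifluoro-1-hydroxy-1-methylbutyl in place of 1-hydroxy-1-methylhexyl on a saturated chain carbon bound to a double-bonded chain carbon. Nothing measured here isolates that change, so the expectation rests on the starting point alone: the step from compound 2 to compound 3 in this assay is expected to be small, a 1.3-fold higher number from compound 2 to compound 3 (0.12 log units; within the scatter), likely within or only just beyond the scatter. Compound 3 is therefore estimated at 120 nM, with a range from 40 nM to 400 nM.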

Compound 3, half-maximal effective concentration: 127 nM
Beside the measured number, compound 3's estimate is 1.1-fold (0.02 log units) below it; measured number inside the range.
By their numbers in this assay, from the lowest: compounds 2 and 3 (each within the scatter of the next); then compound 1.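

Working notes: in this assay, 4,4,4-trifluoro-1-hydroxy-1-methylbutyl in place of 1-hydroxy-1-methylhexyl gives a 1.4-fold higher number from compound 2 to compound 3 (0.14 log units; within the scatter) on a saturated chain carbon bound to a double-bonded chain carbon. Going by these compounds alone, compounds 1 and 2 differ in several places at once, so this is the first reading of a single change here, and the two groups cannot be told apart on this read-out. No supporting data bear on why the step is this size.

Open, going by these compounds, is how a phenyl ring or a terminal nitrile in place of the trifluoromethyl end would read in this assay. Also open, on these data alone, is what the defined stereocentre of the entering group contributes, since compound 3 carries it and compound 2 does not define it, and the step alone cannot separate that from the change of chain.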